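A few compounds are considered here, and "the series" means these few. Any claim that something is new, unique, unknown or untested is made for them only; others in the source may bear on it.

Compound 2 `CC(=O)c1coc(C(=O)CCCCCCc2ccccc2)n1` gives 123 nM in an assay on HEK-293T cells for inhibition of diacylglycerol lipase-alpha (Homo sapiens), read by colorimetric assay; a higher number here means a weaker inhibitor, a lower number a stronger inhibitor; compound 1 `O=C(CCCCCCc1ccccc1)c1nc(C(=O)C(F)(F)F)co1` gives 123 nM, so the two stand level. For the measured compounds named here, the only step seen so far, no change at the digits printed from compound 1 to compound 2 (within the scatter), was no change at the digits printed from compound 1 to compound 2 (within the scatter). Compound 3 `O=C(CCCCCCc1ccccc1)c1nc(C(F)(F)F)co1` differs from compound 2 by trifluoromethyl in place of acetyl on an aromatic carbon. The measured step only swapped groups on that carbonyl carbon and left the carbonyl in place, so removing the acetyl as a whole is an untested change, with no guide to its direction. Compound 3 is therefore expected to give 400 nM (range 100 nM to 2000 nM), a step of a 3.3-fold higher number from compound 2 to compound 3 (0.51 log units; beyond the scatter) that is an estimate only.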

Compound 3, half-maximal inhibitory concentration: 214 nM
Compound 3: middle estimate off by 1.9-fold (0.27 log units), on the high side; low and high end bracket the measured number.
By their numbers in this assay, from the lowest: compounds 1, 2 and 3 (each within the scatter of the next).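

In this assay, the carbonyl attached to this aromatic carbon can be removed without a change beyond the scatter: trifluoromethyl in place of acetyl gives a 1.7-fold higher number from compound 2 to compound 3 (0.24 log units; within the scatter), and trifluoromethyl in place of (trifluoromethyl)carbonyl gives a 1.7-fold higher number from compound 1 to compound 3 (0.24 log units; within the scatter). Among these three compounds, then, a carbonyl at this position is not needed to stay within the scatter. From the compounds shown here alone, whether a carboxylic acid, an amine or a plain hydrogen on this carbon would also stand level remains open. Nothing available explains why these groups read alike.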